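Trifluoromethoxy for trifluoromethyl on the pendant aryl ring

The source may report more compounds than this note shows. Statements on the series, on what has been measured and on what is new or still open speak of the compounds shown alone.

Compound 1 `Oc1ccc(-c2cc(-c3ccccc3C(F)(F)F)cc(-c3cccc(O)c3)n2)cc1` gives 5740 nM in a functional assay on HCT-15 cells (Homo sapiens) for inhibition (on this read-out lower numbers stand for stronger inhibition and higher numbers for weaker inhibition), the lowest of the two numbers in hand. Compound 2 `Oc1ccc(-c2cc(-c3ccc(C(F)(F)F)cc3)cc(-c3cccc(O)c3)n2)cc1` gives 6440 nM in this assay; the step of a 1.1-fold higher number from compound 1 to compound 2 (0.05 log units; within the scatter) shows that moving the trifluoromethyl about its ring leaves the read-out unchanged. Compound 3 `Oc1ccc(-c2cc(-c3ccccc3OC(F)(F)F)cc(-c3cccc(O)c3)n2)cc1` differs from compound 1 by trifluoromethoxy in place of trifluoromethyl on an aromatic carbon. Going by the values given here, no measured step covers an exchange of trifluoromethyl for trifluoromethoxy, and the one step in hand is within the scatter, so the change is expected to give no step beyond the scatter in this assay, that is a 1.0-fold lower number from compound 1 to compound 3 (0.02 log units; within the scatter). Compound 3 is therefore estimated at 5500 nM, with a range of 2500 nM to 12000 nM.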

Compound 3, half-maximal inhibitory concentration: 2310 nM
Compound 3: middle estimate off by 2.4-fold (0.38 log units), on the high side, and the stated range ends above it.
By their numbers in this assay, from the lowest: compound 3; then compounds 1 and 2 (each within the scatter of the next).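

In this assay, going by these compounds alone, a 2.5-fold lower number from compound 1 to compound 3 (0.40 log units; beyond the scatter) makes trifluoromethoxy in place of trifluoromethyl, ortho to a large group, the first change to pass the scatter, though the step is modest. Moving the trifluoromethyl gave only a 1.1-fold higher number from compound 1 to compound 2 (0.05 log units; within the scatter) so the read-out responds to the identity of this group in a way the first pair did not show. Nothing in hand accounts for the difference. Still open, as far as these compounds go, is whether a methoxy group in the same place would follow trifluoromethoxy, and whether trifluoromethoxy keeps this step when placed as the trifluoromethyl of compound 2.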